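The compounds below may be only part of what the source reports. "The series", "measured", "known", "first", "only" and "open" are said of these compounds alone.

Compound 3 `CCOc1ccc(-c2cc(C3CC(C)(C)OC(C)(C)C3)nn2-c2ccccc2OC)cc1` stands second highest of the three measured numbers in an assay on HEK293 cells for inhibition of Voltage-dependent N-type calcium channel subunit alpha-1B (Homo sapiens), read by fluorescence and calcium flux, with a stated time of 5 min; on this read-out higher numbers stand for weaker inhibition and lower numbers for stronger inhibition: compound 1 `COc1ccccc1-n1nc(C2CC(C)(C)OC(C)(C)C2)cc1-c1ccnc(Cl)c1` gives 11 nM, compound 2 `COc1ccccc1-n1nc(C2CC(C)(C)OC(C)(C)C2)cc1-c1ccc(Cl)cc1` gives 1 nM, and compound 3 gives 2 nM. The gap a 2.0-fold higher number from compound 2 to compound 3 (0.30 log units; within the scatter) is within the scatter, whereas the gap a 5.5-fold lower number from compound 1 to compound 3 (0.74 log units; beyond the scatter) is beyond it.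

Compound 4 `COc1ccccc1-n1nc(C2CC(C)(C)OC(C)(C)C2)cc1-c1ccc(C)nc1` differs from compound 3 in one place: 6-methylpyridin-3-yl in place of 4-ethoxyphenyl on an aromatic carbon. The group that enters is a six-membered aromatic ring with one hetero atom, as in compound 1, while the group that leaves is a ring of carbon only, as in compounds 2 and 3. Among the compounds with values here, two measured steps bear on this swap. The step of an 11-fold lower number from compound 1 to compound 2 (1.04 log units; beyond the scatter) and the step of a 5.5-fold lower number from compound 1 to compound 3 (0.74 log units; beyond the scatter) both show that replacing the ring with a hetero atom by a carbon-only ring lowered the number markedly; compound 4 reverses that direction. The 6-methylpyridin-3-yl group is, however, not the 2-chloropyridin-4-yl group of compound 1, so the size of the reversal is uncertain. A modest step upward in this assay is therefore expected, a 3.0-fold higher number from compound 3 to compound 4 (0.48 log units; beyond the scatter). For compound 4 the expected value in this assay is 6 nM, with a range from 2 nM to 20 nM.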

Compound 4, half-maximal inhibitory concentration: 6 nM
Beside the measured number, compound 4's estimate shows no gap at the digits printed; measured number inside the range.
By their numbers in this assay, from the lowest: compounds 2 and 3 (each within the scatter of the next); then compounds 4 and 1 (each within the scatter of the next).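

In this assay, placing the 6-methylpyridin-3-yl group on this aromatic carbon gives a 3.0-fold higher number from compound 3 to compound 4 (0.48 log units; beyond the scatter) and a 6.0-fold higher number from compound 2 to compound 4 (0.78 log units; beyond the scatter) in the same read-out, so the higher numbers are no longer tied to compound 1 alone and now also appear with a six-membered aromatic ring with 1 hetero atom that carries a methyl rather than a chloro group. The two compounds with such a ring sit together, with a 1.8-fold lower number from compound 1 to compound 4 (0.26 log units; within the scatter) as the only step between them, and among these four compounds both give higher numbers than the two compounds with a ring of carbon only, with none going against this pattern. No evidence is available that explains this difference between the ring types.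

The compounds shown leave open whether the ring nitrogen alone sets this gap or the groups on the ring also count, and a 4-methylphenyl group at this position would pair directly with compound 4. They also leave open how the 6-methylpyridin-3-yl ring would read with an amine, a carboxylic acid or a longer chain in place of its methyl.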